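A few compounds are considered here, and "the series" means these few. Any claim that something is new, unique, unknown or untested is made for them only; others in the source may bear on it.

Compound 1 `COc1ccc(/C=C/C(=O)c2ccccc2-c2ccc(F)cc2)cc1` is the reference point of the set. In a functional assay on CNE-2 cells (Homo sapiens) for antiproliferative activity, read by sulforhodamine B assay, with a stated time of 48 h (on this read-out higher numbers stand for weaker inhibition and lower numbers for stronger inhibition), compound 1 gives 53 nM. Compound 2 `COc1ccc(/C=C/C(=O)c2ccccc2-c2ccc(F)nc2)cc1` differs from compound 1 in one place, (6-fluoropyridin-3-yl in place of 4-fluorophenyl on an aromatic carbon), and in this assay compound 2 gives 160 nM; the step is a 3.0-fold higher number from compound 1 to compound 2 (0.48 log units; beyond the scatter).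

Compound 3 `COc1ccc(C(=O)/C=C/c2ccccc2-c2ccc(F)cc2)cc1` has the same atoms as compound 1, joined differently; the difference between the two cores is not broken down here. In this assay compound 3 gives 9000 nM, the highest number among the three measured compounds, beyond the scatter from both compound 1 and compound 2.

Compound 4 `COc1ccc(C(=O)/C=C/c2ccccc2-c2ccc(F)nc2)cc1` stands to compound 3 as compound 2 stands to compound 1, with 6-fluoropyridin-3-yl in place of 4-fluorophenyl on an aromatic carbon. The place of the change is described in the same words for both pairs, on an aromatic carbon of a six-membered aromatic ring of carbon only, ortho to a large group, so it is the same change made on a weaker core. For the measured compounds named here, only one measured instance of it exists, and the expectation rests on that single step. In this assay compound 4 is expected to give 25000 nM, with a range estimated from 9000 nM to 70000 nM. The expected step of a 2.8-fold higher number from compound 3 to compound 4 (0.44 log units; beyond the scatter) is taken directly from a 3.0-fold higher number from compound 1 to compound 2 (0.48 log units; beyond the scatter), with a wider range to allow for the weak starting point of compound 3.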

Compound 4, half-maximal inhibitory concentration: 13000 nM
Beside the measured number, compound 4's estimate is 1.9-fold (0.28 log units) above it; the range from low to high includes it.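

In this assay, placing 6-fluoropyridin-3-yl where 4-fluorophenyl stood on the weaker core gives a 1.4-fold higher number from compound 3 to compound 4 (0.16 log units; within the scatter), so on this core the change cannot be told apart from repeat-measurement noise. For the compounds shown here, although only the step on the core of compound 1 lies beyond the scatter, the two steps cannot be told apart, and the change is consistent with carrying over between these two cores: the same change on two cores in this assay, a 3.0-fold higher number (0.48 log units; beyond the scatter) from compound 1 to compound 2 and a 1.4-fold higher number (0.16 log units; within the scatter) from compound 3 to compound 4, 2.1-fold (0.32 log units) apart, within the scatter of two such steps. This rests on just two matched pairs, so it supports no fixed size for the change and no claim that the core alters it, and it does not show that the change would behave alike on any core beyond these two.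

The compounds shown leave open how an amine or a carboxylic acid in place of the fluorine of 6-fluoropyridin-3-yl would read in this assay. They also leave open whether a longer chain such as ethoxy in place of the methoxy group, which all four compounds share, would leave the difference between the two cores and the size of this step as they stand.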